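The source may report more compounds than this note shows. Statements on the series, on what has been measured and on what is new or still open speak of the compounds shown alone.

Compound 1 `CCC(C)(C)Cc1c[nH]c(CCc2ccc(-c3cccc(C#N)n3)cc2)n1`: 95 nM
Compound 2 `CCC(C)(C)Cc1c[nH]c(CCc2ccc(-c3cccnc3)cc2)n1`: 98 nM

In a functional assay on HEK293 cells for agonist activity at Bombesin receptor subtype-3 (Homo sapiens), read by luminescence and calcium flux, with a stated time of 10 min (on this read-out higher numbers stand for an effect only at larger amounts of compound and lower numbers for an effect already at smaller amounts), compound 1 gives 95 nM and compound 2 gives 98 nM. Compound 2 stands as the higher of the two numbers, and its nearest neighbour is compound 1, separated by a 1.0-fold higher number from compound 1 to compound 2 (0.01 log units; within the scatter), so the two compounds cannot be told apart on this read-out.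

Compound 3 `CCC(C)(C)Cc1c[nH]c(CCc2ccc(N3CCCCC3)cc2)n1` differs from compound 2 by piperidin-1-yl in place of pyridin-3-yl on an aromatic carbon. For the measured compounds named here, the only measured step that bears on this change is a 1.0-fold higher number from compound 1 to compound 2 (0.01 log units; within the scatter), which exchanges one six-membered aromatic ring with one hetero atom for another such ring and leaves both values within the scatter. Going by the values given here, no measured step exchanges an aromatic ring for a non-aromatic one, so the data give no direct guide to the size or direction of such a change.

On this footing compound 3 is expected to lie close to compound 2, and the step from compound 2 to compound 3 is estimated as a 1.5-fold higher number from compound 2 to compound 3 (0.18 log units; within the scatter). In this assay compound 3 is therefore estimated at 150 nM, with a range from 40 nM to 600 nM to reflect the absence of a comparable measured step.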

Compound 3, half-maximal effective concentration: 108 nM
Compound 3: the middle estimate sits 1.4-fold (0.14 log units) above what was measured, within the range that was stated.
By their numbers in this assay, from the lowest: compounds 1, 2 and 3 (each within the scatter of the next).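

In this assay, for the compounds shown here, piperidin-1-yl in place of pyridin-3-yl is the first exchange here of a six-membered aromatic ring for a six-membered non-aromatic ring, and it gives a step within the scatter (a 1.1-fold higher number from compound 2 to compound 3 (0.04 log units; within the scatter)). The comparison with the nitrile-bearing group of compound 1 reads the same way (a 1.1-fold higher number from compound 1 to compound 3 (0.06 log units; within the scatter)), so all three compounds cannot be told apart on this read-out, and at this place, on an aromatic carbon para to a large group, the aromatic character of the ring makes no visible difference among these groups. Nothing at hand explains this tolerance or shows how these groups act at the receptor.

All three groups compared are six-membered rings of equal or greater size, so the compounds shown leave open whether this tolerance extends to a morpholine, a dimethylamino group, a carboxylic acid, a longer alkyl chain or plain hydrogen at the same place. They also leave open whether the agreement among these three groups would hold with a different group on the other side of the shared core.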